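The source may hold more compounds than are shown below. What is called first, only, known or untested is meant among the compounds shown, and "the series" means these compounds.

In a functional assay on HCT-116 cells (Homo sapiens) for antiproliferative activity, read by MTT assay, with a stated time of 48 h (a higher number here means a weaker inhibitor, a lower number a stronger inhibitor), two compounds have been measured so far. Compound 1 (`CCCCCCCCCCC(CCO)n1cnc2c(N)ncnc21`) gives 2590 nM and compound 2 (`CCCCCCCCCCCC(CCO)n1cnc2c(Cl)ncnc21`) gives 7590 nM as the higher of the two numbers, a gap beyond the usual scatter. The next step leads from compound 2 to compound 3 (`CCCCCCCCCCCC(CCO)n1cnc2c(N)ncnc21`), which has amino in place of chloro on an aromatic carbon. Within the data shown here, no measured pair shows this change alone, so its size cannot be read directly. Among the measured compounds shown here, the only guide is compound 1 with 2590 nM as its value, which carries the amino group on a different chain. The step is therefore expected to run towards a lower number and beyond the scatter, an estimated 2.9-fold lower number from compound 2 to compound 3 (0.47 log units; beyond the scatter) in this assay as the likely outcome. For compound 3 the estimated value is 2600 nM with an expected range of 1300 nM to 5200 nM as the likely span.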

Compound 3, half-maximal inhibitory concentration: 13400 nM
Compound 3: the middle estimate sits 5.2-fold (0.71 log units) below what was measured; measured number outside the range, above it.
By their numbers in this assay, from the lowest: compound 1; then compounds 2 and 3 (each within the scatter of the next).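

In this assay, amino in place of chloro on an aromatic carbon gives a 1.8-fold higher number from compound 2 to compound 3 (0.25 log units; within the scatter), so at this position the two groups are not told apart on the longer chain. The chain carbon counts for more in this small set: methyl in place of hydrogen on a saturated chain carbon gives a 5.2-fold higher number from compound 1 to compound 3 (0.71 log units; beyond the scatter). Nothing available accounts for either step.

On these data alone, it remains open whether another group on that aromatic carbon, such as methoxy, methylamino or a plain hydrogen, would stand apart from amino and chloro. Also open, as far as these compounds go, are how the number would follow a shorter or still longer chain, and whether the step between amino and chloro would look the same on the chain of compound 1.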